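Removing the methyl between the ring nitrogens of compound 1

The compounds below may be only part of what the source reports. "The series", "measured", "known", "first", "only" and "open" are said of these compounds alone.

Of the compounds shown here, three sharing one core have been measured in an assay on isolated protein for binding affinity to corticotropin-releasing factor receptor 1 (Homo sapiens); a lower number here means a stronger inhibitor, a higher number a weaker inhibitor. Compound 1 `CCCN(CC1CC1)c1cc(Nc2c(Cl)cc(Cl)cc2Cl)nc(C)n1` gives 30 nM, which is the highest number of the three. Compound 2 `CCCN(CC1CC1)c1nc(C)nc(Nc2c(Cl)cc(Cl)cc2Cl)c1C` gives 2.3 nM, and compound 3 `CCCN(CC1CC1)c1nc(C)nc(Nc2c(Cl)cc(Cl)cc2Cl)c1CC` gives 3.8 nM. The steps from compound 1 to these two are a 13-fold lower number from compound 1 to compound 2 (1.12 log units; beyond the scatter) and a 7.9-fold lower number from compound 1 to compound 3 (0.90 log units; beyond the scatter), while a 1.7-fold higher number from compound 2 to compound 3 (0.22 log units; within the scatter).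

Compound 4 `CCCN(CC1CC1)c1cc(Nc2c(Cl)cc(Cl)cc2Cl)ncn1` is not yet measured. It differs from compound 1 by hydrogen in place of methyl on an aromatic carbon. Within the data shown here, none of the measured steps touches this position: the two large steps from compound 1 concern alkyl groups entering elsewhere on the core, and they say nothing about what the methyl between the two ring nitrogens contributes. With no direct guide, a change at the core is expected to cost some affinity rather than gain it, but the size is uncertain. The step from compound 1 to compound 4 is therefore estimated as a 2.3-fold higher number from compound 1 to compound 4 (0.37 log units; beyond the scatter). Compound 4 is expected to give 70 nM, within a range from 20 nM to 250 nM in this assay .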

Compound 4, inhibition constant: > 10000 nM
Compound 4 was reported as a limit; the forecaster's own chance of this, stated with the estimate: 3%; at least 140-fold (2.15 log units) between middle value and limit.
By their numbers in this assay, from the lowest: compounds 2 and 3 (each within the scatter of the next); then compound 1. At a limit, above all of these: compound 4.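

Among these compounds, the methyl on the aromatic carbon between two ring nitrogen atoms matters far more than the earlier compounds could reveal: with only that methyl leaving and hydrogen entering, the step is an at least 330-fold higher number from compound 1 to compound 4 (2.52 log units; beyond the scatter). This loss is larger than the gain from either alkyl group entering elsewhere on the core, a 13-fold lower number from compound 1 to compound 2 (1.12 log units; beyond the scatter) and a 7.9-fold lower number from compound 1 to compound 3 (0.90 log units; beyond the scatter), so affinity in this assay depends strongly on this position. The reading for compound 4 is a limit rather than a number, so the step gives only a minimum size: the limit of > 10000 nM in this assay, at which 1 of the 4 values shown sits.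

From the compounds shown here alone, it remains open whether methyl is specifically needed here, or whether a longer chain such as ethyl, a methoxy group or an amine at this position would also restore affinity. Going by these compounds, whether hydrogen there costs as much on the core of compound 2, which carries a further methyl, also stays open.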